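From Compound 2 to Compound 4: A Sulfonyl Aryl Swap

A few compounds are considered here, and "the series" means these few. Any claim that something is new, unique, unknown or untested is made for them only; others in the source may bear on it.

Compound 1 `O=S(=O)(Nc1ccc(-c2nc3ccccc3o2)cc1)c1ccccc1C(F)(F)F`: in an assay on isolated protein for inhibition of malate dehydrogenase, mitochondrial (Sus scrofa), with stated times of 45 min and 30 min (a lower number here means a stronger inhibitor, a higher number a weaker inhibitor), compound 1 gives > 63000 nM, a limit of the assay.
Compound 2 `Cc1ccccc1S(=O)(=O)Nc1ccc(-c2nc3ccccc3o2)cc1`: in this assay compound 2 gives > 63000 nM, a limit of the assay.
Compound 3 `O=S(=O)(Nc1ccc2oc(-c3ccccc3)nc2c1)c1ccc(O)cc1`: in this assay compound 3 gives > 63000 nM, a limit of the assay.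

Compound 2 therefore stands at the limit, as do the other two, since (the limit of > 63000 nM in this assay, at which 3 of the 3 values shown sit). Going by the values given here, the only single-point step, a step that the two limits leave unreadable from compound 1 to compound 2, is left unreadable by the two limits. Compound 4 `O=S(=O)(Nc1ccc(-c2nc3ccccc3o2)cc1)c1ccc(Cl)c(Cl)c1` differs from compound 2 by 3,4-dichlorophenyl in place of 2-methylphenyl on a sulfonyl sulfur. Among the compounds with values here, no measured step bears on this change, so nothing points to a step beyond the scatter in either direction. Compound 4 is expected to sit again at the limit, estimated at 63000 nM with a range of 20000 nM to 200000 nM. The step of a number no higher from compound 2 to compound 4 (the limit leaves the size open) is thus expected to be none beyond the scatter.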

Compound 4, half-maximal inhibitory concentration: > 63000 nM
Compound 4 gave a limit, no number; the forecaster's own chance of this, stated with the estimate: 80%; the middle value lies on the limit itself.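

Compound 2 and compound 4 both give only a limit in this assay, so the step between them cannot be read. The compounds shown leave open whether any change to this series gives a measurable value in this assay.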